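The source may report more compounds than this note shows. Statements on the series, on what has been measured and on what is new or still open speak of the compounds shown alone.

Values so far in a physicochemical assay for solubility, read by HPLC, measured as octanol-water partition, at pH 7.4; a lower number here means a less soluble compound, a higher number a more soluble compound
- compound 1 `Clc1ccc2c(NCCCNc3ccnc(N4CCCCC4)n3)ccnc2c1` gives 2020 nM
- compound 2 `Clc1ccc2c(NCCCNc3nccc(N4CCCC4)n3)ccnc2c1` gives 1250 nM
- compound 3 `Clc1ccc2c(NCCCNc3nccc(Cl)n3)ccnc2c1` gives 1810 nM

Compound 3 cannot be separated from compound 1 or compound 2 in this assay because compound 3 at 1810 nM lies within the scatter of both. The three compounds therefore cannot be ranked on these numbers.

The next compound is compound 4 `Clc1ccc2c(NCCCNc3ccnc(Cl)n3)ccnc2c1`, which has the same atoms as compound 3, joined differently. The change is 2-chloropyrimidin-4-yl in place of 4-chloropyrimidin-2-yl on an amine nitrogen and it swaps one chloropyrimidine attachment for the other on the amine nitrogen.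

Going by the values given here, no measured pair isolates this swap. Among the compounds with values here, the only measured step is a 1.4-fold higher number from compound 2 to compound 3 (0.16 log units; within the scatter) and it replaces pyrrolidin-1-yl with chloro, a different kind of change. That step stays within the scatter, and so do the gaps separating compound 3 from the other two values. The data offer no basis for a direction, so no shift beyond the scatter is expected. The expected step is a 1.0-fold lower number from compound 3 to compound 4 (0.00 log units; within the scatter) and it remains an estimate with real uncertainty, since this swap has not been measured in the series. The estimated value for compound 4 is 1800 nM with an expected range from 1000 nM to 3200 nM.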

Compound 4, solubility: 1010 nM
Compound 4: the middle estimate sits 1.8-fold (0.25 log units) above what was measured; low and high end bracket the measured number.
By their numbers in this assay, from the lowest: compounds 4, 2, 3 and 1 (each within the scatter of the next).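

In this assay the attachment swap is now measured directly, in a pair with the same atoms joined differently: 2-chloropyrimidin-4-yl in place of 4-chloropyrimidin-2-yl on an amine nitrogen gives a 1.8-fold lower number from compound 3 to compound 4 (0.25 log units; within the scatter) and stays within the scatter, so this position shows no separable difference between the two attachments. The series also gains a second replacement of a ring amine by chloro on an aromatic carbon: chloro in place of piperidin-1-yl gives a 2.0-fold lower number from compound 1 to compound 4 (0.30 log units; within the scatter) and is likewise within the scatter, as is the earlier chloro for pyrrolidin-1-yl step, so neither replacement separates its pair on these numbers. No measured evidence bears on why these steps take the size they do.

With all four compounds each within the scatter of the next, the series as shown gives no ranking and no direction for either kind of change. Still open, on these data alone, is what a group such as morpholin-4-yl, a carboxylic acid or a primary amine would give in place of the chloro on either attachment, and what a longer chain on the amine nitrogen would give in this assay on the same core.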